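This account rests on a few compounds, and the source may have more. Where it says the series, first, only, none or still open, it means among the compounds named here.

Compound 1 `Cn1c2cnc1OCCCCCCCCOc1ccc(F)cc1-2`: 72000 nM
Compound 2 `C=CCCCCOc1ccccc1-c1cnc(OCCC=C)n1C`: 17000 nM

Of the compounds shown here, two have so far been measured in a functional assay on SK-MEL-28 cells (Homo sapiens) for inhibition, read by colorimetric assay and MTT assay, with a stated time of 72 h; on this read-out higher numbers stand for weaker inhibition and lower numbers for stronger inhibition. Compound 1 gives 72000 nM. In this assay compound 2 gives 17000 nM, the lower of the two numbers; the gap to compound 1 lies beyond the usual scatter of this kind of measurement, so compound 2 is the stronger inhibitor of the pair.

Compound 3 `C=CCCCCOc1ccc(C)cc1-c1cnc(OCCC=C)n1C` has not yet been measured. It differs from compound 2 in one place: methyl in place of hydrogen on an aromatic carbon. Among the measured compounds shown here, no measured pair in this set shows what such a methyl in place of hydrogen on an aromatic carbon does, so the expectation must rest on the small size of the change. In this assay the step of a 1.2-fold lower number from compound 2 to compound 3 (0.08 log units; within the scatter) is expected to be modest, with no clear direction beyond the scatter. Compound 3 is therefore estimated at 14000 nM, with a range from 5000 nM to 40000 nM.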

Compound 3, half-maximal inhibitory concentration: 83000 nM
Compound 3: the middle estimate sits 5.9-fold (0.77 log units) below what was measured; measured number outside the range, above it.
By their numbers in this assay, from the lowest: compound 2; then compounds 1 and 3 (each within the scatter of the next).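

In this assay, a methyl in place of hydrogen on an aromatic carbon gives a 4.9-fold higher number from compound 2 to compound 3 (0.69 log units; beyond the scatter) and so weakens inhibition, even though only one heavy atom enters. Among the compounds shown here, this single-change pair is the first to show that the ring position para to the (hex-5-en-1-yl)oxy group affects activity, and that this methyl is a change for the worse there. No measurement shown here accounts for the loss.

The compounds shown leave open whether the loss is specific to methyl or would also appear with another group at this position, such as a methoxy group, an amine or a carboxylic acid. They also leave open whether the methyl would have the same effect with a longer chain in place of the (hex-5-en-1-yl)oxy group.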